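The source may report more compounds than this note shows. Statements on the series, on what has been measured and on what is new or still open speak of the compounds shown alone.

Working notes on the side chain of compound 3 (`O=C(/C=C/c1ccc(O)cc1)c1c(O)cccc1OCC1CCCCC1`). In a functional assay on HCT-15 cells (Homo sapiens) for antiproliferative activity, read by sulforhodamine B assay (on this read-out lower numbers stand for stronger inhibition of growth and higher numbers for weaker inhibition of growth), compound 3 gives > 30000 nM, which is a limit and not a number. Compound 2 (`O=C(/C=C/c1ccc(O)cc1)c1c(O)cccc1OCCC1CCCCC1`) gives > 30000 nM, also a limit. Compound 3 therefore stands at the limit of > 30000 nM in this assay, at which 2 of the 3 values shown sit, and a step that the two limits leave unreadable from compound 2 to compound 3.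

Going by the values given here, the only true number so far belongs to compound 1 (`CC(C)(C)CCOc1cccc(O)c1C(=O)/C=C/c1ccc(O)cc1`), which carries no ring in its chain and gives 3430 nM.

The change to compound 4 (`CCCCOc1cccc(O)c1C(=O)/C=C/c1ccc(O)cc1`) is propyl in place of cyclohexyl on a saturated chain carbon bound to an oxygen on an aromatic ring, with propyl in place of cyclohexyl on a saturated chain carbon bound to an oxygen on an aromatic ring. Among the compounds with values here, two measured steps bear on it, an at least 8.7-fold higher number from compound 1 to compound 2 (0.94 log units; beyond the scatter) and an at least 8.7-fold higher number from compound 1 to compound 3 (0.94 log units; beyond the scatter). Both introduce cyclohexyl, whereas this change removes it, so a lower number is expected in this assay, though compound 4 may yet stay at the limit. The expected change is an at least 3.7-fold lower number from compound 3 to compound 4 (0.57 log units; beyond the scatter). The estimate for compound 4 is 8000 nM, within an estimated range of 2500 nM to 30000 nM.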

Compound 4, concentration for 50% growth inhibition: > 30000 nM
Compound 4: no number, only a limit (the forecaster's own chance of this, stated with the estimate: 25%); middle value at least 3.7-fold (0.57 log units) from the limit.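

In this assay compound 4 gives > 30000 nM, a limit and not a number, so taking the ring out of the chain does not by itself restore a measurable value. Compound 1 also has no ring in its chain, and ethyl in place of tert-butyl on a saturated chain carbon, two bonds along the chain from an oxygen on an aromatic ring, gives an at least 8.7-fold higher number from compound 1 to compound 4 (0.94 log units; beyond the scatter), so the end of the chain matters even without a ring. The steps to compound 4 from compound 2 and compound 3 cannot be read, and the limit now covers most of the series: the limit of > 30000 nM in this assay, at which 3 of the 4 values shown sit.

No order among compound 2, compound 3 and compound 4 can be drawn from these limits. From the compounds shown here alone, whether an isopropyl end or a terminal amine on the chain would give a number remains open.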